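This account rests on a few compounds, and the source may have more. Where it says the series, first, only, none or still open, it means among the compounds named here.

Working notes on the series, cytotoxicity screen.

Compound 1 `O=C(Nc1ccc(Cl)cc1)C1CCCN(C(=O)c2cccc(-c3nccs3)c2)C1` is the reference point. Within the data shown here, in an ADME assay on PC-3 cells (Homo sapiens) for cytotoxicity, read by WST assay, tested at 100 uM (on this read-out higher numbers stand for more inhibition at the one concentration tested (going by the name of the read-out) and lower numbers for less inhibition), compound 1 gives 32%, the highest of the three numbers so far. Compound 2 `COC(=O)c1cccc(NC(=O)C2CCCN(C(=O)c3cc(C(F)(F)F)cc(C(F)(F)F)c3)C2)c1` gives 0% in this assay, and compound 3 `O=C(Nc1cccc(S(=O)(=O)N2CCCC2)c1)C1CCCN(C(=O)c2cc(C(F)(F)F)cc(C(F)(F)F)c2)C1` gives 0%; both sit well below compound 1, and their gap to it lies beyond the scatter. Among the measured compounds shown here, the only measured step between neighbours, no change at the digits printed from compound 2 to compound 3 (within the scatter), concerns the anilide side of the shared core and shows nothing at this concentration.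

Compound 4 `O=C(c1ccccc1)c1cccc(C(=O)N2CCCC(C(=O)Nc3ccc(Cl)cc3)C2)c1` is the next member. It differs from compound 1 on the acyl side of the core: benzoyl in place of 1,3-thiazol-2-yl on an aromatic carbon. For the measured compounds named here, no measured pair changes this position, so the step from compound 2 to compound 3 gives no direct guide, and the aryl amides carrying bis(trifluoromethyl)benzoyl (compound 2, compound 3) are inert in this assay, leaving compound 1 as the sole member with a signal. Going by the values given here, with no step on this aryl ring to lean on, the expectation is a modest movement at most, within or just beyond the scatter, and the direction is uncertain.

The estimate for compound 4 in this assay is 25%, with a range from 0% to 55%, meaning an expected step of a number 7 percentage points lower from compound 1 to compound 4 (within the scatter).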

Compound 4, a percentage reported as inhibition, at one concentration (the size of the read-out at that concentration, not a potency): 0%
Compound 4: the middle estimate sits 25 percentage points above what was measured; measured number inside the range.
By their numbers in this assay, from the lowest: compounds 2, 3 and 4 (each within the scatter of the next); then compound 1.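

Among these compounds, on the acyl side of the shared core, the group on this aromatic carbon matters in this assay: with benzoyl in place of 1,3-thiazol-2-yl, the result is a number 32 percentage points lower from compound 1 to compound 4 (beyond the scatter) and is the first step to lie beyond the scatter. Among the compounds shown here, the only earlier step, no change at the digits printed from compound 2 to compound 3 (within the scatter), concerned the anilide side and showed nothing, so this pair is the first sign that the read-out responds to a change in the molecule. The signal of compound 1 does not survive the exchange, since compound 4 gives 0%, and nothing measured on these compounds accounts for the loss.

Going by these compounds, a single pair cannot separate the departure of 1,3-thiazol-2-yl from the arrival of benzoyl, so it remains open whether the signal follows that particular five-membered ring or would persist with another group on the same carbon, such as an oxazole, a pyridine or a plain methoxy. Also open, on these data alone, is whether a dimethylamino group or a carboxylic acid at this place would give any signal in this assay at all.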